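The compounds below may be only part of what the source reports. "The series", "measured", "known", "first", "only" and "open" are said of these compounds alone.

Of the compounds shown here, three built on one shared core have so far been tested in an ADME assay on L02 cells (Homo sapiens) for cytotoxicity, read by MTT assay, with a stated time of 24 h; on this read-out higher numbers stand for lower toxicity in this test and lower numbers for higher toxicity in this test. Compound 1, `O=c1[nH]cc(S(=O)(=O)Nc2ccccc2-c2cn(-c3ccccc3F)nn2)c(=O)[nH]1`, and compound 2, `O=c1[nH]cc(S(=O)(=O)Nc2ccccc2-c2cn(-c3ccccc3Cl)nn2)c(=O)[nH]1`, differ only in the halogen on the outer ring. For compound 1 this assay reports only a limit, > 100000 nM. Compound 2 gives 22800 nM in this assay. Among the compounds with values here, this is the single step measured so far: an at least 4.3-fold lower number from compound 1 to compound 2 (0.64 log units; beyond the scatter). Compound 3, `O=c1[nH]cc(S(=O)(=O)Nc2cccc(-c3cn(-c4ccccc4)nn3)c2)c(=O)[nH]1`, carries the same rings but joined at a different point of the middle ring. For compound 3 this assay again reports only a limit, > 100000 nM. Where compound 3 stands can therefore be said only in part: it sits at the limit of > 100000 nM in this assay, at which 2 of the 3 values shown sit, and a true number for it is not known.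

The unmeasured compound 4, `O=c1[nH]cc(S(=O)(=O)Nc2cccc(-c3cn(-c4ccccc4Cl)nn3)c2)c(=O)[nH]1`, differs from compound 3 in one place: chloro in place of hydrogen on an aromatic carbon. Within the data shown here, the one measured step that bears on this change is an at least 4.3-fold lower number from compound 1 to compound 2 (0.64 log units; beyond the scatter), where chloro likewise entered the same outer ring, though there in place of fluoro. A step of comparable size, downward, toward higher toxicity, is therefore expected here, with the caution that compound 3 starts from a limit rather than a number. For compound 4 the expected step is an at least 2.5-fold lower number from compound 3 to compound 4 (0.39 log units; beyond the scatter). Compound 4 is thus estimated at 40000 nM in this assay, with a range from 15000 nM to 110000 nM.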

Compound 4, half-maximal cytotoxic concentration: 11500 nM
Compound 4: middle estimate off by 3.5-fold (0.54 log units), on the high side; measured number below the stated range.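

Placing chloro on the outer ring, on an aromatic carbon that held only hydrogen, moves the read-out in this assay toward higher toxicity: an at least 8.6-fold lower number from compound 3 to compound 4 (0.93 log units; beyond the scatter). Until now chloro had been seen only replacing fluoro, in compounds whose rings are joined at one point of the middle ring; here it replaces hydrogen, and the rings are joined at a different point, yet the number still falls, so both steps shown that bring in chloro point the same way, and no pair shown goes against this. Each of these two steps starts from a limit rather than a true number, so each printed size is only a lower bound on the real change: the limit of > 100000 nM in this assay, at which 2 of the 4 values shown sit.

As far as these compounds go, whether this drop belongs to chloro in particular stays open, since a methyl group, a methoxy group or an amine on the same ring carbon would be needed to tell it apart from the effect of any other group placed there. Also open, from the compounds shown here alone, is whether chloro elsewhere on the outer ring would lower the number in the same way.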